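The compounds below may be only part of what the source reports. "The series", "measured", "known", "first", "only" and "open" are said of these compounds alone.

Working notes on the series. The three measured compounds share one core and differ only in the amine on the thiocarbonyl carbon. Compound 1 `Nc1ccccc1NC(=O)c1ccc(CSC(=S)N2CCN(c3ccc(Cl)cc3)CC2)cc1` has been run in a functional assay on A-375 cells (Homo sapiens) for antiproliferative activity, read by CCK-8 assay, with a stated time of 72 h, tested at 2 uM (on this read-out lower numbers stand for a weaker effect and higher numbers for a stronger effect at the one concentration tested), where compound 1 gives 32.2%. Compound 2 `CCN(Cc1ccncc1)C(=S)SCc1ccc(C(=O)Nc2ccccc2N)cc1` gives 67.2% in this assay, and compound 3 `Nc1ccccc1NC(=O)c1ccc(CSC(=S)N2CCCc3ccccc32)cc1` gives 26.5%. Compound 1 therefore stands second highest of the three: its value and that of compound 3 lie within the scatter of each other, while compound 2 is beyond the scatter above it. Among the measured compounds shown here, the only single-place step among the measured compounds is a number 40.7 percentage points lower from compound 2 to compound 3 (beyond the scatter), a large fall.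

Compound 4 `Nc1ccccc1NC(=O)c1ccc(CSC(=S)N2CCN(Cc3ccccc3)CC2)cc1` is not yet measured. It differs from compound 1 by benzyl in place of 4-chlorophenyl on an amine nitrogen in a ring. For the measured compounds named here, no measured step changes the group on this ring nitrogen; the step from compound 2 to compound 3 exchanges the whole amine and bears only loosely on the present change, showing that the amine end of the molecule can move this assay strongly in either direction. Going by the values given here, with no closer precedent, the expectation is a step of a number 2.8 percentage points higher from compound 1 to compound 4 (within the scatter) that stays within the scatter. Compound 4 is estimated at 35%, with a range from 18% to 55%.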

Compound 4, a percentage reported as inhibition, at one concentration (the size of the read-out at that concentration, not a potency): 10.6%
Beside the measured number, compound 4's estimate is 24.4 percentage points above it, outside the stated range (below it).
By their numbers in this assay, from the lowest: compound 4; then compounds 3 and 1 (each within the scatter of the next); then compound 2.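

In this assay, among the compounds shown here, benzyl in place of 4-chlorophenyl on the amine nitrogen in the six-membered non-aromatic ring gives a number 21.6 percentage points lower from compound 1 to compound 4 (beyond the scatter) and is the first change confined to this position. The assay therefore responds to a local change at this nitrogen, not only to exchange of the whole amine, even though the leaving and entering groups have the same count of heavy atoms, one six-membered aromatic ring of carbon only, no hydrogen-bond donors or acceptors and no net charge. No measurement at hand explains the difference between the two groups.

The step combines two alterations, the loss of chlorine and the gain of a carbon, and the compounds shown do not separate them. What an unsubstituted phenyl group or a 4-chlorobenzyl group would give on this ring nitrogen remains open, and with it which of the two alterations accounts for the step.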